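A few compounds are considered here, and "the series" means these few. Any claim that something is new, unique, unknown or untested is made for them only; others in the source may bear on it.

Measured in a functional assay on HCT-116 cells (Homo sapiens) for inhibition, read by sulforhodamine B assay, with a stated time of 3 days (a lower number here means a stronger inhibitor of growth, a higher number a weaker inhibitor of growth), are three compounds.
- Compound 1 (`Cc1ccc(COc2ccc(C(=O)/C=C/c3ccccc3)cc2)cc1`) gives > 50000 nM (a limit)
- Compound 2 (`O=C(/C=C/c1cccc([N+](=O)[O-])c1)c1ccccc1`) gives 4470 nM (a number)
- Compound 3 (`O=C(/C=C/c1ccccc1)c1ccc(OCc2ccccc2)cc1`) gives > 50000 nM (a limit)

Compound 1 stands at the limit of > 50000 nM in this assay, at which 2 of the 3 values shown sit, and so has a limit, not a number. Compound 4 (`Cc1ccc(COc2ccc(C(=O)/C=C/c3ccc(F)cc3)cc2)cc1`) differs from compound 1 by fluoro in place of hydrogen on an aromatic carbon. Within the data shown here, the only measured step is a step that the two limits leave unreadable from compound 1 to compound 3 and it gives no size to carry over. Among the measured compounds shown here, no measured pair shows this fluoro change. The estimated step is a number no higher from compound 1 to compound 4 (the limit leaves the size open) in this assay and none beyond the scatter is expected, so compound 4 may well return a limit too. Compound 4 is estimated at 50000 nM (expected range 15000 nM to 100000 nM).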

Compound 4, concentration for 50% growth inhibition: > 50000 nM
Compound 4 gave a limit, no number (the forecaster's own chance of this, stated with the estimate: 75%); the middle value sits exactly at the limit.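

Compound 4 gives > 50000 nM in this assay, a limit and not a number. Compound 1 also stands at a limit, so no step can be read between compound 1 and compound 4. The compounds shown leave open what fluoro in place of hydrogen does to growth inhibition.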